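A few compounds are considered here, and "the series" means these few. Any claim that something is new, unique, unknown or untested is made for them only; others in the source may bear on it.

Measured compounds in a functional assay on CCRF-CEM cells (Homo sapiens) for antiproliferative activity, read by trypan blue exclusion, with a stated time of 72 h; on this read-out lower numbers stand for stronger inhibition and higher numbers for weaker inhibition:
Compound 1 `Cc1ccc(NC(=O)C(C)Br)cc1C(=O)NC(N)=O` gives > 20000 nM; this is a limit of the assay, not a number.
Compound 2 `CC(Br)C(=O)Nc1ccc(F)c(C(=O)NC(N)=O)c1` gives 520 nM.
Compound 3 `Cc1ccc(NC(=O)CI)cc1C(=O)NC(N)=O` gives 20000 nM.

The change from compound 1 to compound 2 is fluoro in place of methyl on an aromatic carbon. In this assay it produced an at least 38-fold lower number from compound 1 to compound 2 (1.58 log units; beyond the scatter), though the starting point is a limit (the limit of > 20000 nM in this assay, at which 1 of the 3 values shown sits), so only a floor for the step is known.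

The two cores differ as iodomethyl in place of 1-bromoethyl on a carbonyl carbon. In this assay the comparison reads a number no higher from compound 1 to compound 3 (the limit leaves the size open).

Compound 4 `NC(=O)NC(=O)c1cc(NC(=O)CI)ccc1F` is not yet measured. It differs from compound 3 by fluoro in place of methyl on an aromatic carbon. The surroundings of the place differ from the earlier case: there the ring carbon was para to a ((1-bromoethyl)carbonyl)amino group, here it is para to a ((iodomethyl)carbonyl)amino group, so this is the same kind of change, not the same change.

In this assay compound 4 is expected to show a 33-fold lower number from compound 3 to compound 4 (1.52 log units; beyond the scatter), the expectation resting on the step from compound 1 to compound 2, an at least 38-fold lower number from compound 1 to compound 2 (1.58 log units; beyond the scatter). Compound 4 is estimated at 600 nM, with a likely range from 150 nM to 3000 nM.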

Compound 4, half-maximal inhibitory concentration: < 10 nM
Compound 4: only a limit was reported; the forecaster's own chance of this, stated with the estimate: 5%; middle value at least 60-fold (1.77 log units) from the limit.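

In this assay, fluoro in place of methyl on an aromatic carbon gives an at least 2000-fold lower number from compound 3 to compound 4 (3.30 log units; beyond the scatter), so the direction seen on the core of compound 1 carries over to the core of compound 3: the same change on two cores in this assay, an at least 38-fold lower number (1.58 log units; beyond the scatter) from compound 1 to compound 2 and an at least 2000-fold lower number (3.30 log units; beyond the scatter) from compound 3 to compound 4; the limit leaves it open whether they differ

Compound 4 gives < 10 nM; this is a limit of the assay, not a number.

Iodomethyl in place of 1-bromoethyl gives an at least 52-fold lower number from compound 2 to compound 4 (1.71 log units; beyond the scatter), but the pairs show only a shared direction for each change, not a size that can be carried from one core to the other: the same change on two cores in this assay, a number no higher (the limit leaves the size open) from compound 1 to compound 3 and an at least 52-fold lower number (1.71 log units; beyond the scatter) from compound 2 to compound 4; the limit leaves it open whether they differ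

The compounds shown leave open whether the large steps belong to fluoro itself or would also appear with chloro or a methoxy group on the same ring carbon. They also leave open how far the result depends on the carbamoylcarbamoyl group, which a carboxylic acid or a simple primary amide could test, and whether a chloromethyl or bromomethyl group in place of iodomethyl would give a value that is a number rather than a limit.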